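This account rests on a few compounds, and the source may have more. Where it says the series, first, only, none or still open, it means among the compounds named here.

Of the compounds shown here, two built around a shared core have been measured in an assay on HEK293 cells for positive allosteric modulation of metabotropic glutamate receptor 2 (Rattus norvegicus), read by thallium flux; a higher number here means that more compound is needed for the effect, a lower number that less compound is needed. Compound 1 `O=C(O)c1cc(-c2cccc(COc3ccc4c(=O)n(C5CCCC5)oc4c3)c2)ccc1Cl` gives 310 nM in this assay. Compound 2 `O=C(O)c1cc(-c2cccc(COc3ccc4c(c3)CN(CC3CC3)C4=O)c2)ccc1Cl` gives 80 nM in this assay, the lowest of the two numbers; the number for compound 1 is higher by a gap that lies beyond the usual scatter of repeated measurements. Since compound 1 and compound 2 differ in more than one place, that gap cannot be tied to a single change.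

Compound 3 `O=C(O)c1cc(-c2cccc(COc3ccc4c(c3)CN(c3ccccc3)C4=O)c2)ccc1Cl` has not yet been measured and differs from compound 2 in exactly one place: phenyl in place of cyclopropylmethyl on an amide-type nitrogen in a ring. Among the compounds with values here, no measured pair shows what such a swap does here, so the expectation rests on compound 2 alone. A small rise, within the usual scatter, is the expected step of a 1.9-fold higher number from compound 2 to compound 3 (0.27 log units; within the scatter) in this assay. Compound 3 is therefore estimated at 150 nM, with a range from 40 nM to 600 nM.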

Compound 3, half-maximal effective concentration: 260 nM
The estimate for compound 3 lay 1.7-fold (0.24 log units) below the measured number, within the range that was stated.
By their numbers in this assay, from the lowest: compound 2; then compounds 3 and 1 (each within the scatter of the next).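

In this assay, phenyl in place of cyclopropylmethyl on an amide-type nitrogen in a ring gives a 3.3-fold higher number from compound 2 to compound 3 (0.51 log units; beyond the scatter) and so counts as a modest loss. Within the data shown here, this is the first difference in the set that can be tied to a single change, and it shows that the number responds to what sits on this nitrogen. Compound 3 still gives a measurable effect with the aromatic ring in place, so phenyl is accepted here, though more compound is needed than with cyclopropylmethyl.

Nothing available explains why the number rises with this swap.
A cyclohexyl ring, a benzyl group or a short chain carrying an amine on the same nitrogen would help show whether the aromatic ring, the larger group or something else goes with the higher number.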